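From propyl to pentyl at the assay limit

This account rests on a few compounds, and the source may have more. Where it says the series, first, only, none or still open, it means among the compounds named here.

- Compound 1 `COc1cc(-c2nccn2C)cc(OC)c1OC` gives > 100000 nM (a limit)
- Compound 2 `CCCn1ccnc1-c1cc(OC)c(OC)c(OC)c1` gives > 100000 nM (a limit)
- Compound 3 `COc1cc(-c2nccn2CC(C)C)cc(OC)c1OC` gives > 100000 nM (a limit)

In a functional assay on MDA-MB-468 cells (Homo sapiens) for antiproliferative activity, read by MTT assay, with a stated time of 72 h (a higher number here means a weaker inhibitor, a lower number a stronger inhibitor), compound 2 gives > 100000 nM, which is a limit and not a number. The two other measured compounds stand at the same kind of limit, so compound 2 has no readable position among them.

Compound 4 `CCCCCn1ccnc1-c1cc(OC)c(OC)c(OC)c1` differs from compound 2 by one change on the chain: ethyl in place of hydrogen on a saturated chain carbon, three bonds along the chain from an aromatic nitrogen. The same difference, read on the whole chain, is propyl to pentyl.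

Among the compounds with values here, three measured steps bear on this change, all on the same chain: a step that the two limits leave unreadable from compound 1 to compound 2, a step that the two limits leave unreadable from compound 1 to compound 3 and a step that the two limits leave unreadable from compound 2 to compound 3. None of them has a size that can be read, so they offer no measured trend to extend. The plain expectation is little or no change in this assay, because the limit of > 100000 nM in this assay, at which 3 of the 3 values shown sit, leaves no chain in the series with a number. A reported limit is therefore more likely than not for the next compound.

The expected change is an at least 1.1-fold lower number from compound 2 to compound 4 (0.04 log units; that floor lies within the scatter), and it is not expected to exceed the usual scatter. Compound 4 is estimated at 90000 nM. The estimated range for compound 4 runs from 30000 nM to 150000 nM.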

Compound 4, half-maximal inhibitory concentration: 57900 nM
Beside the measured number, compound 4's estimate is 1.6-fold (0.19 log units) above it; measured number inside the range.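

Within the data shown here, the pentyl chain gives the first reading that is a number and not a limit, and in this assay the change from propyl to pentyl is an at least 1.7-fold lower number from compound 2 to compound 4 (0.23 log units; that floor lies within the scatter). Measured against the other two chains on the same aromatic nitrogen, the result reads an at least 1.7-fold lower number from compound 3 to compound 4 (0.23 log units; that floor lies within the scatter) and an at least 1.7-fold lower number from compound 1 to compound 4 (0.23 log units; that floor lies within the scatter). Each of these steps is only a floor that lies within the scatter, so the pentyl chain is shown to reach a readable value but the true size of the change stays unknown, and the steps among compound 1, compound 2 and compound 3 cannot be read: the limit of > 100000 nM in this assay, at which 3 of the 4 values shown sit.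

The compounds shown leave open whether a longer chain, such as hexyl or octyl, would give a lower number in this assay or a value back at the limit. They also leave open whether a chain of this length carrying an amine or a carboxylic acid would keep a readable value, and whether a branched chain of the same length would read like the straight pentyl chain.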